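Thiophen-2-yl in Place of Phenyl: An Expected Limit

The compounds below may be only part of what the source reports. "The series", "measured", "known", "first", "only" and "open" are said of these compounds alone.

Compound 1 `C=C1C(=O)O[C@H]2CC3=C[C@H](C/C(C)=C/[C@@H](OC(=O)c4ccc(C(F)(F)F)cc4)[C@H]12)OC3=O` gives in a functional assay on NCI-H460 cells (Homo sapiens) for cytotoxicity, read by MTT assay, with a stated time of 48 h; a higher number here means a weaker inhibitor, a lower number a stronger inhibitor > 10000 nM, which is a limit of the assay and not a number.
Compound 2 `C=C1C(=O)O[C@H]2CC3=C[C@H](C/C(C)=C/[C@@H](OC(=O)/C=C/c4ccccc4)[C@H]12)OC3=O` gives in this assay > 10000 nM, again a limit of the assay and not a number.

For the measured compounds named here, the only measured step, a step that the two limits leave unreadable from compound 1 to compound 2, shows 2-phenylethenyl in place of 4-(trifluoromethyl)phenyl on a carbonyl carbon, but its size cannot be read, since both ends are limits. Compound 2 therefore stands at the limit, as does every value shown: the limit of > 10000 nM in this assay, at which 2 of the 2 values shown sit.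

Compound 3 `C=C1C(=O)O[C@H]2CC3=C[C@H](C/C(C)=C/[C@@H](OC(=O)/C=C/c4cccs4)[C@H]12)OC3=O` differs from compound 2 by thiophen-2-yl in place of phenyl on a double-bonded chain carbon bound to a double-bonded chain carbon. Going by the values given here, no measured step bears on this change in a readable way; the one step available is itself unreadable. Because the limit of > 10000 nM in this assay, at which 2 of the 2 values shown sit, places both measured compounds at the limit, no potency beyond that limit is evident in the shared core with either aromatic group tried, and compound 3 is expected to behave much the same. Compound 3 is therefore estimated to give 15000 nM in this assay, most likely reported again only as a limit, within a range of 5000 nM to 50000 nM. The step this estimate means, a step that the limit leaves unreadable from compound 2 to compound 3, is expected to be no change beyond the scatter.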

Compound 3, half-maximal inhibitory concentration: 2900 nM
Beside the measured number, compound 3's estimate is 5.2-fold (0.71 log units) above it; the measured number lies below the stated range.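

For the compounds shown here, the aromatic ring on a double-bonded chain carbon bound to a double-bonded chain carbon turns out to matter in this assay: thiophen-2-yl in place of phenyl produces the first measurable number of the series, with (an at least 3.4-fold lower number from compound 2 to compound 3 (0.53 log units; beyond the scatter)) as the step. The larger change on a carbonyl carbon, 2-(thiophen-2-yl)ethenyl in place of 4-(trifluoromethyl)phenyl, reads the same way, with (an at least 3.4-fold lower number from compound 1 to compound 3 (0.53 log units; beyond the scatter)) as the step, while the step between the two compounds at the limit cannot be read. The shared core can therefore give a measurable number with the right group at this place, and compound 3 alone does so, with the other two compounds remaining at a limit of the assay and not a number: the limit of > 10000 nM in this assay, at which 2 of the 3 values shown sit.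

As far as these compounds go, how large the two readable steps really are stays open, since each has a limit at one end. From the compounds shown here alone, it also stays open whether the sulfur atom or the five-membered ring goes with the gain, a question that furan-2-yl, with oxygen in the ring, or thiophen-3-yl, joined through another ring carbon, could help to answer.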